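Dimethylamino for Phenoxy: Expected Cytotoxicity of Compound 4

The source may report more compounds than this note shows. Statements on the series, on what has been measured and on what is new or still open speak of the compounds shown alone.

Of the compounds shown here, three have so far been measured in a functional assay on A549 cells (Homo sapiens) for cytotoxicity, read by sulforhodamine B assay, with a stated time of 48 h, tested at 100 nM; on this read-out higher numbers stand for a weaker effect at the one concentration tested and lower numbers for a stronger effect. Compound 1 `COc1cc(C)cc(-c2c(-c3ccnc(-c4ccc(C(C)=O)cc4)c3)cnn2CC#N)c1` gives 83% in this assay, compound 2 `COc1cc(C)cc(-c2nn(CC#N)cc2-c2ccc(-c3cccc(C(C)=O)c3)nc2)c1` gives 91%, and compound 3 `Cc1cc(O)cc(-c2nn(CC#N)cc2-c2ccnc(-c3ccc(Oc4ccccc4)cc3)c2)c1` gives 87%. Among these three numbers compound 3 stands second highest. Its nearest neighbour is compound 1, whose number lies within the scatter of that of compound 3, and its furthest is compound 2, whose number also lies within the scatter. Among the compounds with values here, no two of the measured compounds differ in only one place, so no single step between measured compounds can be read from the numbers; all that can be said is that all three values lie close together.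

Compound 4 `Cc1cc(O)cc(-c2nn(CC#N)cc2-c2ccnc(-c3ccc(N(C)C)cc3)c2)c1` has not yet been measured. It differs from compound 3 in one place: dimethylamino in place of phenoxy on an aromatic carbon. The phenoxy leaves and the dimethylamino enters on an aromatic carbon of a six-membered aromatic ring of carbon only, para to a large group.

Since the three measured compounds, which differ among themselves at several places, all fall within the scatter of one another, the step of a number 1 percentage points lower from compound 3 to compound 4 (within the scatter) is expected to stay within the scatter, in no clear direction. Compound 4 is therefore estimated to give 86% in this assay, in a range from 72% to 98%.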

Compound 4, a percentage reported as activity, at one concentration (the size of the read-out at that concentration, not a potency): 95%
Beside the measured number, compound 4's estimate is 9 percentage points below it; low and high end bracket the measured number.
By their numbers in this assay, from the lowest: compounds 1, 3, 2 and 4 (each within the scatter of the next, the first and the last beyond it).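

In this assay, within the data shown here, the exchange at this place, an aromatic carbon of a six-membered aromatic ring of carbon only, para to a large group, gives the first step that can be read: a number 8 percentage points higher from compound 3 to compound 4 (within the scatter) when dimethylamino takes the place of phenoxy. The earlier compounds shown here differ in several places at once and could not isolate any single position, whereas this pair shows that phenoxy, with 7 heavy atoms and a ring, can give way to dimethylamino, with 3 heavy atoms and no ring, while the read-out stays within the scatter. Nothing at hand accounts for this outcome.

Going by these compounds, whether other groups at this place, such as a primary amine, a morpholine ring or a carboxylic acid, would also stay within the scatter remains open, and one step between two groups cannot show a trend at this position. On these data alone, it is also open whether the same exchange would give a similar step on the core of compound 1, and how either compound would read at other concentrations.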